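Swapping fluorine for chlorine on the carbamoyl phenyl

The compounds below may be only part of what the source reports. "The series", "measured", "known", "first", "only" and "open" are said of these compounds alone.

Compound 3 `CC(C)=CCC/C(C)=C/CC1Cc2c(OC(=O)Nc3ccc(F)cc3)cc(=O)n(CCCO)c2CC1(C)C` gives 6.2% in a functional assay on PANC-1 cells (Homo sapiens) for inhibition, read by MTT assay, with a stated time of 24 h, tested at 10 uM (on this read-out lower numbers stand for less inhibition and higher numbers for more inhibition at the one concentration tested (going by the name of the read-out)), the highest of three numbers. Going by the values given here, compound 2 `CC(C)=CCC/C(C)=C/COc1cc(=O)n(CCCO)c2c1CC(C/C=C(\C)CCC=C(C)C)C(C)(C)C2` gives 3.1%, and compound 1 `CC(C)=CCC/C(C)=C/CC1Cc2c(O)cc(=O)n(CCCO)c2CC1(C)C` gives 0%; the steps of a number 3.1 percentage points higher from compound 1 to compound 2 (within the scatter), a number 6.2 percentage points higher from compound 1 to compound 3 (within the scatter) and a number 3.1 percentage points higher from compound 2 to compound 3 (within the scatter) all lie within the scatter, so no compound stands apart. Compound 4 `CC(C)=CCC/C(C)=C/CC1Cc2c(OC(=O)Nc3ccc(Cl)cc3)cc(=O)n(CCCO)c2CC1(C)C` differs from compound 3 by chloro in place of fluoro on an aromatic carbon. Among the compounds with values here, each measured step changes the group on the oxygen of the aromatic ring; none touches the (4-fluorophenyl)carbamoyl group itself, so no measured step bears directly on this change. With all three compounds near zero, compound 4 is expected to stay near them, with a number 1.8 percentage points higher from compound 3 to compound 4 (within the scatter), a step within the scatter. The estimate for compound 4 is 8%, between 0% and 25%.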

Compound 4, a percentage reported as inhibition, at one concentration (the size of the read-out at that concentration, not a potency): 4.3%
For compound 4 the middle estimate is 3.7 percentage points above the measured one; low and high end bracket the measured number.
By their numbers in this assay, from the lowest: compounds 1, 2, 4 and 3 (each within the scatter of the next).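

Of the steps shown, only one changes the phenyl ring of the carbamoyl group itself: chloro in place of fluoro on an aromatic carbon gives a number 1.9 percentage points lower from compound 3 to compound 4 (within the scatter) in this assay. The (4-chlorophenyl)carbamoyl group also stays close to the other groups on the oxygen, with a number 1.2 percentage points higher from compound 2 to compound 4 (within the scatter) and a number 4.3 percentage points higher from compound 1 to compound 4 (within the scatter), so this swap does not set compound 4 apart. Nothing available explains these numbers.

Open, as far as these compounds go, is whether an amine or a carboxylic acid in place of the halogen, or an alkyl chain in place of the phenyl ring, would give a number beyond the scatter.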